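A Difluorophenyl Swap Against a Cytotoxicity Limit

The source may hold more compounds than are shown below. What is called first, only, known or untested is meant among the compounds shown, and "the series" means these compounds.

Of the compounds shown here, two sharing one core have been read in an ADME assay on HepG2 cells (Homo sapiens) for cytotoxicity; on this read-out higher numbers stand for an effect only at larger amounts of compound and lower numbers for an effect already at smaller amounts. Compound 1 `Cc1ccc(S(=O)(=O)N[C@@H](CC(=O)NC(C)(C)C)C(=O)NCCNC(=O)c2cccc(F)c2)cc1` gives > 11000 nM, which is a limit of the assay. Compound 2 `Cc1ccc(S(=O)(=O)N[C@@H](CC(=O)NC(C)(C)C)C(=O)NCCNC(=O)c2ccc(Cl)cc2)cc1` gives > 11000 nM, which is also a limit, so compound 2 stands without a number of its own.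

Compound 3 `Cc1ccc(S(=O)(=O)N[C@@H](CC(=O)NC(C)(C)C)C(=O)NCCNC(=O)c2ccc(F)c(F)c2)cc1` differs from compound 2 by 3,4-difluorophenyl in place of 4-chlorophenyl on a carbonyl carbon, with 3,4-difluorophenyl in place of 4-chlorophenyl on a carbonyl carbon. For the measured compounds named here, the one measured step at that place is a step that the two limits leave unreadable from compound 1 to compound 2. All the data show there is the limit of > 11000 nM in this assay, at which 2 of the 2 values shown sit.

Given a step that the two limits leave unreadable from compound 1 to compound 2, no shift beyond the scatter is expected in this assay, in either direction. The expected step is a step that the limit leaves unreadable from compound 2 to compound 3. Compound 3 is estimated at 14000 nM, with an expected range from 7000 nM to 30000 nM, and most likely only a limit will be reported.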

Compound 3, half-maximal effective concentration: > 11000 nM
Compound 3: a limit, no number (the forecaster's own chance of this, stated with the estimate: 85%); the middle value does not contradict the limit.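

In this assay compound 3 gives > 11000 nM, which is a limit and not a number. No step among compound 1, compound 2 and compound 3 can be read: the limit of > 11000 nM in this assay, at which 3 of the 3 values shown sit.

The compounds shown leave open at what concentration any of the three would show an effect, and whether their aromatic groups make any difference to it.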